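The compounds below may be only part of what the source reports. "The series", "measured", "known", "first", "only" and "open" are said of these compounds alone.

Measured in a functional assay on NCI-H23 cells (Homo sapiens) for inhibition, read by sulforhodamine B assay, with a stated time of 48 h, tested at 10 uM (a lower number here means less inhibition, a higher number more inhibition at the concentration tested (going by the name of the read-out)), so far:
- compound 1 `Brc1cn2ccnc2c(-c2ccc3ncn(C4CCCCC4)c3c2)n1`: 10.2%
- compound 2 `c1ccc(-c2cn3ccnc3c(-c3ccc4ncn(C5CCCCC5)c4c3)n2)cc1`: 45.3%
- compound 3 `c1ccc2c(-c3cn4ccnc4c(-c4ccc5ncn(C6CCCCC6)c5c4)n3)cccc2c1`: 4.32%

In this assay compound 1 stands second highest of the three. Its smaller step, a number 5.9 percentage points lower from compound 1 to compound 3 (within the scatter), lies within the scatter, while the larger one, a number 35.1 percentage points higher from compound 1 to compound 2 (beyond the scatter), lies beyond it.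

Compound 4 `c1cn2cc(-c3ccsc3)nc(-c3ccc4ncn(C5CCCCC5)c4c3)c2n1` differs from compound 1 in one place: thiophen-3-yl in place of bromo on an aromatic carbon

Among the compounds with values here, two measured steps bear on this change. Replacing the bromo with phenyl gave a number 35.1 percentage points higher from compound 1 to compound 2 (beyond the scatter), a large rise; replacing it with naphthalen-1-yl gave a number 5.9 percentage points lower from compound 1 to compound 3 (within the scatter), no change beyond the scatter. Thiophen-3-yl brings a single five-membered aromatic ring, which resembles the phenyl case more than the two-ring naphthalen-1-yl case, so a rise is expected, though its size is uncertain. Compound 4 is therefore expected to give 32%, within the range 8% to 56%. The expected step is a number 21.8 percentage points higher from compound 1 to compound 4 (beyond the scatter).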

Compound 4, a percentage reported as inhibition, at one concentration (the size of the read-out at that concentration, not a potency): 10%
The estimate for compound 4 lay 22 percentage points above the measured number, within the range that was stated.
By their numbers in this assay, from the lowest: compounds 3, 4 and 1 (each within the scatter of the next); then compound 2.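

In this assay the step of a number 35.3 percentage points lower from compound 2 to compound 4 (beyond the scatter) sets thiophen-3-yl apart from phenyl at this position, so a single aromatic ring in place of the bromo does not by itself bring the rise. The steps of a number 0.2 percentage points lower from compound 1 to compound 4 (within the scatter) and a number 5.7 percentage points higher from compound 3 to compound 4 (within the scatter) place thiophen-3-yl level with bromo and naphthalen-1-yl, leaving phenyl alone among the four groups shown. No evidence here accounts for the gap between phenyl and thiophen-3-yl. Still open, from the compounds shown here alone, is whether a phenyl carrying an amine or a carboxylic acid would keep the higher number.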